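Trifluoromethyl in Place of Fluoro: An Untested Step

The compounds below may be only part of what the source reports. "The series", "measured", "known", "first", "only" and "open" are said of these compounds alone.

Three compounds sharing one core were tested in a functional assay on HeLa cells (Homo sapiens) for inhibition; on this read-out higher numbers stand for weaker inhibition and lower numbers for stronger inhibition. Compound 2 `Oc1cccc(-c2cc(-c3cccc(F)c3)cc(-c3cccc(O)c3)n2)c1` gives 1400 nM, the lowest of the two numbers shown. Compound 3 `Oc1ccc(-c2cc(-c3cccc(F)c3)cc(-c3cccc(O)c3)n2)cc1` gives 14200 nM, which is a 10-fold higher number from compound 2 to compound 3 (1.01 log units; beyond the scatter). Compound 1 `Oc1cccc(-c2cc(-c3cccc(F)c3)cc(-c3ccccc3O)n2)c1` reaches only a limit of this assay, > 50000 nM. The steps of an at least 35-fold lower number from compound 1 to compound 2 (1.55 log units; beyond the scatter) and an at least 3.5-fold lower number from compound 1 to compound 3 (0.54 log units; beyond the scatter) likewise concern where the hydroxyl sits on one outer ring. Compound 4 `Oc1cccc(-c2cc(-c3cccc(C(F)(F)F)c3)cc(-c3cccc(O)c3)n2)c1` differs from compound 2 by trifluoromethyl in place of fluoro on an aromatic carbon on the other outer ring. None of the measured steps touches that ring, so nothing shown tells how this assay answers such a change. Compound 4 is therefore expected to give about 1500 nM, with a range of 400 nM to 6000 nM. The expected step of a 1.1-fold higher number from compound 2 to compound 4 (0.03 log units; within the scatter) is estimated to stay within the scatter.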

Compound 4, half-maximal inhibitory concentration: 12700 nM
Compound 4: middle estimate off by 8.5-fold (0.93 log units), on the low side; the whole stated range lies below it.
By their numbers in this assay, from the lowest: compound 2; then compounds 4 and 3 (each within the scatter of the next). At a limit, above all of these: compound 1.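

For the compounds shown here, the ring carrying the fluoro group, which no earlier step touched, is not indifferent to change: trifluoromethyl in place of fluoro gives a 9.1-fold higher number from compound 2 to compound 4 (0.96 log units; beyond the scatter) in this assay. Inhibition in these compounds therefore depends on this outer ring as well as on where the hydroxyl sits, and here the larger group gives the weaker inhibition. Nothing shown here explains why this step weakens inhibition.

As far as these compounds go, it remains open whether chloro or methyl at this place would keep the number of compound 2. From the compounds shown here alone, whether the fluoro is needed at all, which hydrogen in its place would test, also remains open.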